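Replacing 2-ethylbutyl on the shared core of compound 3

The compounds below may be only part of what the source reports. "The series", "measured", "known", "first", "only" and "open" are said of these compounds alone.

Compound 1 (`CCc1nc(-c2ccc(Cl)cc2Cl)c(CC)nc1NC(C1CC1)C1CC1`): 0.0417 h
Compound 2 (`CCc1nc(N(CC2CC2)CC2CC2)c(CC)nc1-c1ccc(Cl)cc1Cl`): < 0.0167 h
Compound 3 (`CCc1nc(-c2ccc(Cl)cc2Cl)c(CC)nc1CC(CC)CC`): 0.0417 h

All three values come from an in vitro ADME assay on microsomes (Rattus norvegicus) for metabolic stability (on this read-out lower numbers stand for a shorter-lived compound and higher numbers for a longer-lived compound), and the notes below refer to that read-out. For compound 2 the entry < 0.0167 h is a limit and not a number, namely the limit of < 0.0167 h in this assay, at which 1 of the 3 values shown sits, in this series. Compound 3 at 0.0417 h stands level with compound 1 and clear of compound 2.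

The next structure is compound 4 (`CCc1nc(-c2ccc(Cl)cc2Cl)c(CC)nc1NC(C)CN(C)C`), with (1-((dimethylamino)methyl)ethyl)amino in place of 2-ethylbutyl on an aromatic carbon. Among the measured compounds shown here, two measured steps bear on this swap, both ending on 2-ethylbutyl. One is no change at the digits printed from compound 1 to compound 3 (within the scatter) and lies within the scatter, with 2-ethylbutyl in place of (dicyclopropylmethyl)amino. The other is an at least 2.4-fold higher number from compound 2 to compound 3 (0.39 log units; beyond the scatter) and lies beyond the scatter, with 2-ethylbutyl in place of bis(cyclopropylmethyl)amino. Read backwards, neither step shows an amino group giving a higher number than 2-ethylbutyl, and one shows a lower number.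

No rise is therefore expected in this assay, and the expected outcome is no step beyond the scatter, with any drift more likely downward. The expected step is a 1.3-fold lower number from compound 3 to compound 4 (0.10 log units; within the scatter) on this estimate. Compound 4 is estimated at 0.033 h (expected range 0.017 h to 0.08 h).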

Compound 4, half-life: < 0.0167 h
Compound 4: no number, only a limit; the forecaster's own chance of this, stated with the estimate: 25%; middle value at least 1.9-fold (0.29 log units) away from the limit.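

In this assay, the (1-((dimethylamino)methyl)ethyl)amino group in place of 2-ethylbutyl gives an at least 2.4-fold lower number from compound 3 to compound 4 (0.39 log units; beyond the scatter), so this position on the shared core does not treat every amino group alike and, unlike the earlier swap to (dicyclopropylmethyl)amino, this swap moves the read-out beyond the scatter. The amino link alone does not settle the outcome: with 1-((dimethylamino)methyl)ethyl in place of dicyclopropylmethyl on the same nitrogen, the result is an at least 2.4-fold lower number from compound 1 to compound 4 (0.39 log units; beyond the scatter), while compound 1 and compound 3 print the same number. Compound 4 gives < 0.0167 h, which is a limit and not a number, and its step to compound 2 cannot be read, as compound 2 also stands at a limit: the limit of < 0.0167 h in this assay, at which 2 of the 4 values shown sit.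

As far as these compounds go, the actual size of the drop stays open, as does whether it follows the dimethylamino end of the new chain or some other part of that chain. An isopropylamino group, or a chain on the same nitrogen ending in a hydroxyl group or a morpholine in place of the dimethylamino end, would help to separate these readings.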